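Trifluoromethyl Replacing Hydrogen: Cytotoxicity Outlook for Compound 4

A few compounds are considered here, and "the series" means these few. Any claim that something is new, unique, unknown or untested is made for them only; others in the source may bear on it.

Of the compounds shown here, three sharing one core have been measured in an ADME assay on HepG2 cells (Homo sapiens) for cytotoxicity, read by luminescence, CellTiter-Glo and ATP content, with a stated time of 72 h; a higher number here means that more compound is needed for the effect, a lower number that less compound is needed. Compound 1 `FC(F)(F)c1ccc(-c2ccc3c(NCCCNCc4ccco4)ccnc3c2)cc1` gives 3470 nM. Compound 2 `COc1cccc(CNCCCNc2ccnc3cc(-c4ccc(F)cc4)ccc23)c1O` gives 6840 nM. Compound 3 `COc1cccc(CNCCCNc2ccnc3cc(-c4ccccc4)ccc23)c1O` gives 3210 nM, the lowest of the three numbers, although its gap to compound 1 lies within the scatter and only its gap to compound 2 lies beyond it.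

Compound 4 `COc1cccc(CNCCCNc2ccnc3cc(-c4ccc(C(F)(F)F)cc4)ccc23)c1O` differs from compound 3 by trifluoromethyl in place of hydrogen on an aromatic carbon. Within the data shown here, the only single-point step in this set, a 2.1-fold lower number from compound 2 to compound 3 (0.33 log units; beyond the scatter), swapped a halogen for hydrogen on the same ring and moved the number modestly. Among the measured compounds shown here, compound 1 also carries a trifluoromethyl group on that ring, and its value of 3470 nM sits within the scatter of compound 3, though the two compounds also differ elsewhere, so no step between them is given.

Taking both together, the step of a 1.1-fold higher number from compound 3 to compound 4 (0.05 log units; within the scatter) is expected to stay within or only just beyond the scatter, if anything toward a higher number. Compound 4 is therefore estimated at 3600 nM, with a range from 1700 nM to 7600 nM.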

Compound 4, half-maximal effective concentration: 2210 nM
Compound 4: middle estimate off by 1.6-fold (0.21 log units), on the high side; low and high end bracket the measured number.
By their numbers in this assay, from the lowest: compounds 4, 3, 1 and 2 (each within the scatter of the next, the first and the last beyond it).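

With trifluoromethyl on the aromatic carbon para to a large group, this assay shows a 1.5-fold lower number from compound 3 to compound 4 (0.16 log units; within the scatter) so this larger group cannot be told apart from hydrogen at this position. Set against fluoro at the same carbon, trifluoromethyl gives a 3.1-fold lower number from compound 2 to compound 4 (0.49 log units; beyond the scatter) and, together with a 2.1-fold lower number from compound 2 to compound 3 (0.33 log units; beyond the scatter) this leaves compound 2 as the one compound of the three in this series whose number lies beyond the scatter from both others, so the size of the group does not order these values. With trifluoromethyl held in place on the ring, the change on the chain gives a 1.6-fold lower number from compound 1 to compound 4 (0.20 log units; within the scatter) and so 2-hydroxy-3-methoxyphenyl and furan-2-yl cannot be told apart on this ring background.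

Going by these compounds, whether chloro or a nitrile at this carbon would fall with fluoro or with hydrogen and trifluoromethyl remains open. Nothing available explains why fluoro stands apart.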